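The source may report more compounds than this note shows. Statements on the series, on what has been measured and on what is new or still open speak of the compounds shown alone.

Among the compounds with values here, compound 1 `COc1ccc(N(CC(=O)NCCC[Te]c2ccccc2)C(=O)CNC(=O)OC(C)(C)C)cc1` is the only compound here with a definite number: in a functional assay on Hs-578T cells (Homo sapiens) for inhibition, with a stated time of 48 h (on this read-out lower numbers stand for stronger inhibition of growth and higher numbers for weaker inhibition of growth), compound 1 gives 7240 nM. Compound 2 `CC1=C(SCCC(=O)OCC(=O)NCCC[Te]c2ccccc2)C(=O)c2ccccc2C1=O` stands apart, as in this assay compound 2 reaches only a limit of the measurement, < 100000 nM, not a number (the limit of < 100000 nM in this assay, at which 1 of the 2 values shown sits). Compound 3 `COc1ccc(N(CC(=O)NCCC[Te]c2ccccc2)C(=O)c2ccccc2)cc1` differs from compound 1 in one place: phenyl in place of ((tert-butoxycarbonyl)amino)methyl on a carbonyl carbon. Within the data shown here, no measured pair shows such a step, so its size is open; the step from compound 1 to compound 3 is estimated at a 1.4-fold lower number from compound 1 to compound 3 (0.16 log units; within the scatter), a small move towards stronger inhibition. Compound 3 is therefore expected to reach about 5000 nM, within a range of 1500 nM to 20000 nM.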

Compound 3, concentration for total growth inhibition: 871 nM
The estimate for compound 3 lay 5.7-fold (0.76 log units) above the measured number; the whole stated range lies above it.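

In this assay, the group on the carbonyl carbon whose other neighbour is the amide-type nitrogen clearly matters: phenyl in place of ((tert-butoxycarbonyl)amino)methyl gives an 8.3-fold lower number from compound 1 to compound 3 (0.92 log units; beyond the scatter), a move towards stronger inhibition of growth. Within the data shown here, this single pair is the first measured sign that this place can shift the read-out beyond the usual scatter. It also shows that an aromatic ring is accepted here in place of an open chain.

A free aminomethyl group or a cyclohexyl ring at this place could help separate losing the old chain from gaining the ring, but the compounds shown leave that open. The values shown give no reason for the step.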